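A few compounds are considered here, and "the series" means these few. Any claim that something is new, unique, unknown or untested is made for them only; others in the source may bear on it.

Measured compounds:
compound 1, `CCCCCCCCCCCCCCCCc1c(C)c(N(C)C)nc(C)c1O`: 80%
compound 2, `Cc1c(N(C)C)nc(CCCCCCCCCCO)c(O)c1C`: 20%

Both were read in a functional assay on cells (Lymphocyte), read by a luciferase reporter and ATP content, with a stated time of 48 h, tested at 10 uM; on this read-out lower numbers stand for a stronger effect and higher numbers for a weaker effect at the one concentration tested. In this assay compound 2 gives 20%, the lowest of the two numbers and so the stronger effect; compound 1 gives 80%, a number higher by a margin beyond the usual scatter. Among the compounds with values here, no pair of measured compounds differs in only one place, so no single structural change has yet been tied to a measured step. Compound 3, `CCCCCCCCCCc1nc(N(C)C)c(C)c(C)c1O`, has not yet been measured in this assay. It differs from compound 2 by hydrogen in place of hydroxy on a saturated chain carbon, ten or more bonds along the chain from an aromatic carbon. Compound 1 also carries a saturated chain without a hydroxy, though its chain is longer, and compound 1 gives 80%. On that basis compound 3 is expected to move toward a weaker effect, with an estimated step of a number 35 percentage points higher from compound 2 to compound 3 (beyond the scatter). For compound 3 the estimate is 55%, in the range 25% to 85%.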

Compound 3, a percentage reported as activity, at one concentration (the size of the read-out at that concentration, not a potency): 52%
Estimate against measurement, compound 3: 3 percentage points above; the measured number falls inside the stated range.
By their numbers in this assay, from the lowest: compound 2; then compound 3; then compound 1.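

In this assay, within the data shown here, hydrogen in place of hydroxy on a saturated chain carbon, ten or more bonds along the chain from an aromatic carbon, gives a number 32 percentage points higher from compound 2 to compound 3 (beyond the scatter) and so ties a measured step to one structural change for the first time. The hydroxy at this place therefore matters: the loss of this one oxygen atom and its hydrogen comes with a weaker effect at the single concentration tested. Nothing measured here explains why the step has this size.

Still open, going by these compounds, is whether an amine, a carboxylic acid or a methoxy group at this same place would give a number like that of compound 2. Among these compounds, also open is how a longer chain ending in a hydroxy would read, since chain length has not yet been varied on its own.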